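The source may hold more compounds than are shown below. What is called first, only, known or untested is meant among the compounds shown, and "the series" means these compounds.

Measured so far in an ADME assay on PA-1 cells (Homo sapiens) for cytotoxicity, read by MTT assay, with a stated time of 72 h; on this read-out lower numbers stand for stronger inhibition and higher numbers for weaker inhibition:
- compound 1 `COc1ccc(C2=C(c3cc(OC)c(OC)c(OC)c3)C(=O)CC2O[SiH2]C(C)(C)C)cc1OC`: > 100 ug/mL 
- compound 2 `COc1ccc(C2=C(c3cc(OC)c(OC)c(OC)c3)C(=O)C(O[SiH2]C(C)(C)C)C2)cc1OC(C)C`: 7.1 ug/mL 
- compound 3 `COc1ccc(C2=C(c3cc(OC)c(OC)c(OC)c3)C(=O)C(O)C2)cc1NC(=O)c1ccccc1`: > 100 ug/mL 

Compound 1 reaches only the limit of this assay, reported as > 100 ug/mL. Compound 3 likewise reaches only a limit, reported as > 100 ug/mL. For the measured compounds named here, compound 2 therefore stands alone as the one compound with an actual number in this assay, 7.1 ug/mL; the other two values sit at the limit of > 100 ug/mL in this assay, at which 2 of the 3 values shown sit. Going by the values given here, no two of the three compounds differ in a single place, so no measured step can be drawn between them.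

Compound 4 `COc1ccc(C2=C(c3cc(OC)c(OC)c(OC)c3)C(=O)C(OC(C)=O)C2)cc1OC(C)C` has not yet been measured. It differs from compound 2 in one place: a group of 3 heavy atoms (2 carbon, 1 oxygen; no ring) in place of a group of 5 heavy atoms (4 carbon, 1 silicon; no ring), on an oxygen on a saturated carbon. The oxygen that carries the group stays where it is; only the group attached to it changes. Among the compounds with values here, with no measured step to lean on, the account can only expect, and it expects a moderate loss from compound 2 to compound 4 in this assay, the step of a 2.8-fold higher number from compound 2 to compound 4 (0.45 log units; beyond the scatter) beyond the usual scatter but not large. Compound 4 is thus estimated at 20 ug/mL, with a range from 5 ug/mL to 100 ug/mL.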

Compound 4, half-maximal inhibitory concentration: > 100 ug/mL
Compound 4 gave a limit, no number (the forecaster's own chance of this, stated with the estimate: 30%); middle value at least 5.0-fold (0.69 log units) away from the limit.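

In this assay, what this oxygen on a saturated carbon carries clearly matters: acetyl in place of the group of 5 heavy atoms (4 carbon, 1 silicon) gives an at least 14-fold higher number from compound 2 to compound 4 (1.14 log units; beyond the scatter). For the compounds shown here, this is the first measured single-place change in the set, as no earlier pair differed in only one place. Compound 4 gives only a limit, so the full size of the step remains unknown, and it joins the other compounds at that limit: the limit of > 100 ug/mL in this assay, at which 3 of the 4 values shown sit.

The compounds shown leave open whether the silicon atom is needed or whether another group on this oxygen, such as a benzoyl group or a longer alkyl chain, could keep a measurable value. The free hydroxyl on this carbon appears only in compound 3, which also differs elsewhere, so its effect here cannot be read.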